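From furan-3-yl to 2-phenylethenyl on the shared core

The source may hold more compounds than are shown below. What is called first, only, known or untested is meant among the compounds shown, and "the series" means these compounds.

Within the data shown here, compound 1 `CCCCC#Cc1cc([C@@H]2O[C@H](CO)[C@@H](O)[C@H]2O)n2ncnc(N)c12` with hex-1-yn-1-yl gives 200 nM in a functional assay on Z-138 cells (Homo sapiens) for antiproliferative activity, with a stated time of 72 h (a higher number here means a weaker inhibitor, a lower number a stronger inhibitor), and compound 2 `Nc1ncnn2c([C@@H]3O[C@H](CO)[C@@H](O)[C@H]3O)cc(-c3ccoc3)c12` with furan-3-yl gives 300 nM and these are the only two numbers so far. Among the measured compounds shown here, compound 2 therefore cannot be told apart from compound 1, its only neighbour on the scale.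

Compound 3 `Nc1ncnn2c([C@@H]3O[C@H](CO)[C@@H](O)[C@H]3O)cc(/C=C/c3ccccc3)c12` keeps the core of compound 2 and differs in one place, with 2-phenylethenyl in place of furan-3-yl on an aromatic carbon as the whole change.

For the measured compounds named here, one measured step bears on this carbon. The exchange of hex-1-yn-1-yl for furan-3-yl gave a 1.5-fold higher number from compound 1 to compound 2 (0.18 log units; within the scatter) and so left the number within the scatter. Going by the values given here, a single step is thin evidence, and no measured compound yet carries 2-phenylethenyl. No step beyond the scatter is therefore expected in this assay and no firm direction can be given, although the range must stay wide. Estimated for compound 3 are 400 nM as the middle and 120 nM to 1400 nM as the range. This estimate amounts to a 1.3-fold higher number from compound 2 to compound 3 (0.12 log units; within the scatter) as the expected outcome.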

Compound 3, half-maximal inhibitory concentration: 1300 nM
For compound 3 the middle estimate is 3.3-fold (0.51 log units) below the measured one; the range from low to high includes it.
By their numbers in this assay, from the lowest: compounds 1 and 2 (each within the scatter of the next); then compound 3.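

Until now this aromatic carbon had carried hex-1-yn-1-yl and furan-3-yl with no difference that could be read between them. Among these compounds, with 2-phenylethenyl, this assay shows for the first time that the number depends on the group at this position, with a 4.3-fold higher number from compound 2 to compound 3 (0.64 log units; beyond the scatter), and the same exchange starting from hex-1-yn-1-yl gives a 6.5-fold higher number from compound 1 to compound 3 (0.81 log units; beyond the scatter), so 2-phenylethenyl stands apart from both earlier groups by steps beyond the scatter. No measurement available here accounts for this difference.

The compounds shown leave open whether the higher number goes with the six-membered aromatic ring of carbon only or with the double bond outside aromatic rings, as 2-phenylethenyl brings both at once and a phenyl group set directly on this carbon would be needed to separate them. Equally open, on these data alone, is how the number would move with an amine, a carboxylic acid or a saturated hexyl chain at the same place on the shared core.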